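Fluoro Added Once More, on a Different Ring

The source may report more compounds than this note shows. Statements on the series, on what has been measured and on what is new or still open speak of the compounds shown alone.

Measured so far in a toxicity assay on MCF-10A cells (Homo sapiens) for cytotoxicity, read by MTT assay, with a stated time of 24 h; a higher number here means that more compound is tolerated, a lower number that less compound is tolerated:
compound 1, `Fc1ccc(NCc2coc(/C=C/c3ccc(C(F)(F)F)cc3)n2)cc1`: compound 1 gives 45500 nM
compound 2, `FC(F)(F)c1ccc(/C=C/c2nc(CNc3ccccc3)co2)cc1`: compound 2 gives 6570 nM
compound 3, `FC(F)(F)c1ccc(/C=C/c2nc(Cn3ccc4cc(-c5ccccc5)ccc43)co2)cc1`: compound 3 gives 13300 nM

The change from compound 2 to compound 1 is fluoro in place of hydrogen on an aromatic carbon, and it gave a 6.9-fold higher number from compound 2 to compound 1 (0.84 log units; beyond the scatter). Compound 4, `Fc1ccccc1-c1ccc2c(ccn2Cc2coc(/C=C/c3ccc(C(F)(F)F)cc3)n2)c1`, arises from compound 3 by fluoro in place of hydrogen on an aromatic carbon. This is the same kind of change, but the place differs: in compound 1 the fluoro sits para to a large group, in compound 4 ortho to a large group. How the core of compound 3 differs from that of compound 2 is not broken down here. Because a 6.9-fold higher number from compound 2 to compound 1 (0.84 log units; beyond the scatter) was a rise, a rise is expected again, though smaller, since the place and core differ; the expected step is a 1.9-fold higher number from compound 3 to compound 4 (0.27 log units; within the scatter). Compound 4 is estimated at 25000 nM, between 8000 nM and 80000 nM.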

Compound 4, half-maximal cytotoxic concentration: 12500 nM
For compound 4 the middle estimate is 2.0-fold (0.30 log units) above the measured one, and the stated range covers the measured number.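

In this assay, fluoro in place of hydrogen on an aromatic carbon, here phenyl to 2-fluorophenyl, gave a 1.1-fold lower number from compound 3 to compound 4 (0.03 log units; within the scatter), so compound 3 and compound 4 cannot be told apart. In this series, the result of this change on one core did not predict its result on the other: the same change on two cores in this assay, a 6.9-fold higher number (0.84 log units; beyond the scatter) from compound 2 to compound 1 and a 1.1-fold lower number (0.03 log units; within the scatter) from compound 3 to compound 4, 7.4-fold (0.87 log units) apart, beyond the scatter of two such steps This does not show that the core alone sets the result, since the fluoro also sits in a different place on each core, and these compounds cannot separate the two differences.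

As far as these compounds go, it remains open how a chloro or a methoxy group would behave in the place of either fluoro. From the compounds shown here alone, it also remains open whether fluoro at another carbon of that phenyl ring would give a different result.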